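Series notes: amine substituent step, compound 2 to compound 3

The compounds below may be only part of what the source reports. "The series", "measured", "known", "first", "only" and "open" are said of these compounds alone.

Measured so far:
compound 1 `CCNCc1cc(C)cc(Nc2nc3ccccc3n2Cc2ccc(C(F)(F)F)cc2)c1O` 18800 nM
compound 2 `CCNCc1cc(Cl)cc(Nc2nc3ccccc3n2Cc2ccc(C(F)(F)F)cc2)c1O` 33800 nM

For the measured compounds named here, in an ADME assay on CHO cells (Cricetulus griseus) for inhibition, read by MTT assay (on this read-out higher numbers stand for weaker inhibition and lower numbers for stronger inhibition), compound 2 gives 33800 nM, the highest of the two numbers; its only neighbour is compound 1 with 18800 nM, and the step of a 1.8-fold higher number from compound 1 to compound 2 (0.25 log units; within the scatter) stays within the scatter. Compound 3 `CC(C)(C)NCc1cc(Cl)cc(Nc2nc3ccccc3n2Cc2ccc(C(F)(F)F)cc2)c1O` differs from compound 2 by tert-butyl in place of ethyl on an amine nitrogen. Going by the values given here, no measured step touches the ethylamino to (tert-butyl)amino change; the one known step concerns the aromatic substituent only. With nothing to lean on, no step beyond the scatter is expected, so compound 3 is estimated at 34000 nM (range 12000 nM to 95000 nM), an expected step of a 1.0-fold higher number from compound 2 to compound 3 (0.00 log units; within the scatter).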

Compound 3, half-maximal inhibitory concentration in the CHO assay: 36300 nM
The estimate for compound 3 lay 1.1-fold (0.03 log units) below the measured number; the measured number falls inside the stated range.
By their numbers in the CHO assay, from the lowest: compounds 1, 2 and 3 (each within the scatter of the next).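

In the CHO assay, tert-butyl in place of ethyl on the amine nitrogen gives a 1.1-fold higher number from compound 2 to compound 3 (0.03 log units; within the scatter), so this read-out does not separate the two groups. In a physicochemical assay for solubility, read by HPLC, measured as kinetic solubility, with a stated time of 24 h, at pH 6.5 (on this read-out higher numbers stand for higher solubility and lower numbers for lower solubility), compound 2 gives 12000 nM, and the same change gives an at least 2.4-fold lower number from compound 2 to compound 3 (0.38 log units; beyond the scatter), so the two read-outs part at this position. In the physicochemical assay compound 3 gives < 5000 nM, which is a limit of the assay: the limit of < 5000 nM in the physicochemical assay, at which 1 of the 2 values shown sits.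

As far as these compounds go, the actual number for compound 3 in the physicochemical assay stays open. Also open, from the compounds shown here alone, is how a hydroxyethyl chain or a morpholine at this amine nitrogen would read in either assay.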